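The source may hold more compounds than are shown below. What is called first, only, known or untested is meant among the compounds shown, and "the series" means these compounds.

Compound 2 `O=C(CCCCCCc1ccccc1)c1nncs1` is an alpha-keto heterocycle in which the carbonyl carries a seven-carbon chain ending in a phenyl ring. In an assay for inhibition of Fatty-acid amide hydrolase 1 (Rattus norvegicus), at pH 9.0 (a higher number here means a weaker inhibitor, a lower number a stronger inhibitor), compound 2 gives 1.4 nM. Compound 1 `O=C(CCCCCCc1ccccc1)c1ncno1`, which differs only in the ring attached to the carbonyl, gives 1 nM in this assay; the step of a 1.4-fold higher number from compound 1 to compound 2 (0.15 log units; within the scatter) lies within the scatter. On the two numbers shown compound 2 stands highest, but the gap to compound 1 does not separate the two.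

Compound 3 `O=C(CCCCCCc1ccccc1)c1nnc(-c2ccco2)s1` differs from compound 2 by furan-2-yl in place of hydrogen on an aromatic carbon. No measured step bears on this kind of change: the one step shown, from compound 1 to compound 2, exchanges the whole ring at the carbonyl rather than decorating it, and it was within the scatter in any case. The expectation for compound 3 therefore rests on little, and the estimated step of a 1.8-fold lower number from compound 2 to compound 3 (0.24 log units; within the scatter) is set close to no change in this assay, with a wide range in both directions. Compound 3 is expected to give about 0.8 nM, between 0.1 nM and 6 nM.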

Compound 3, inhibition constant: 7.4 nM
The estimate for compound 3 lay 9.3-fold (0.97 log units) below the measured number; measured number outside the range, above it.
By their numbers in this assay, from the lowest: compounds 1 and 2 (each within the scatter of the next); then compound 3.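

In this assay, furan-2-yl in place of hydrogen on the aromatic carbon next to the ring nitrogen and next to the ring sulfur gives a 5.3-fold higher number from compound 2 to compound 3 (0.72 log units; beyond the scatter), the only step shown that lies beyond the scatter. Among these compounds, the exchange of the whole ring at the carbonyl, a 1.4-fold higher number from compound 1 to compound 2 (0.15 log units; within the scatter), had left the number within the scatter, so this position is the first place where a single change visibly weakens inhibition, although the loss is modest and compound 3 still gives 7.4 nM. Nothing available explains the loss, and no measurement bears on why this group at this position raises the number.

With one group at this position, the compounds shown leave open whether the loss belongs to furan-2-yl itself or would follow from any group there, such as a methyl, a phenyl, an amine or a carboxylic acid. They also leave open whether furan-2-yl would have a step of similar size on the 1,2,4-oxadiazol-5-yl ring of compound 1, or with a shorter or longer chain at the carbonyl.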